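This account rests on a few compounds, and the source may have more. Where it says the series, first, only, none or still open, it means among the compounds named here.

Compound 1 `COc1cc2ncnc(NNC(=S)NC(=O)c3ccccc3C)c2cc1OC`, compound 3 `COc1cc2ncnc(NNC(=S)NC(=O)c3ccccc3)c2cc1OC` and compound 2 `O=C(NC(=S)NNc1ncnc2ccccc12)c1ccc(C(F)(F)F)cc1` were all tested in a functional assay on MCF7 cells (Homo sapiens) for cytotoxicity, read by MTT assay, with a stated time of 72 h; a lower number here means a stronger inhibitor, a higher number a weaker inhibitor. Compound 1 gives 19300 nM, compound 3 gives 6990 nM and compound 2 gives 8050 nM. Compound 2 thus stands second highest of the three numbers; its gap to compound 3 lies within the scatter, while compound 1 sits further off, beyond it. The only single-point step among these compounds, a 2.8-fold lower number from compound 1 to compound 3 (0.44 log units; beyond the scatter), concerns hydrogen in place of methyl on an aromatic carbon and does not touch the ring altered here. Compound 4 `O=C(NC(=S)NNc1ncnc2ccccc12)c1ccc(F)cc1` arises from compound 2 by fluoro in place of trifluoromethyl on an aromatic carbon. For the measured compounds named here, with no measured step on that group, the expected change, a 1.1-fold higher number from compound 2 to compound 4 (0.05 log units; within the scatter), stays within the scatter. Compound 4 is estimated at 9000 nM, between 4000 nM and 20000 nM.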

Compound 4, half-maximal inhibitory concentration: 4590 nM
The estimate for compound 4 lay 2.0-fold (0.29 log units) above the measured number; low and high end bracket the measured number.
By their numbers in this assay, from the lowest: compounds 4, 3 and 2 (each within the scatter of the next); then compound 1.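

In this assay, for the compounds shown here, fluoro in place of trifluoromethyl gives a 1.8-fold lower number from compound 2 to compound 4 (0.24 log units; within the scatter), the first measured step at this position, on an aromatic carbon para to a large group. Going from four heavy atoms to one here therefore does not move the number beyond the scatter. Nothing measured here bears on the cause of this result.

The compounds shown leave open whether an amine or a carboxylic acid at this position would move the number beyond the scatter. They also leave open whether the same change behaves alike on the core of compound 3.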